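Extending Methylamino to Propylamino on the Shared Core

This account rests on a few compounds, and the source may have more. Where it says the series, first, only, none or still open, it means among the compounds named here.

Of the compounds shown here, three share a core and have been measured in a functional assay on MDA-MB-231 cells (Homo sapiens) for cytotoxicity, read by MTT assay, with a stated time of 72 h, tested at 5 uM, in the absence of a further agent; on this read-out higher numbers stand for a weaker effect at the one concentration tested and lower numbers for a stronger effect. Compound 1 `CC1(C)CC(=O)Nc2ccc(Cl)cc21` gives 81.7% in this assay. Compound 2 `CC1(C)CC(=S)Nc2ccc(Cl)cc21` gives 94.3%. Compound 3 `CNC1=Nc2ccc(Cl)cc2C(C)(C)C1` gives 92.3%, the second highest of the three numbers; its nearest neighbour is compound 2, whose number lies within the scatter of it, while compound 1 stands a full step beyond the scatter below it. For the measured compounds named here, no single-point change between measured compounds is available, so no measured step can guide the next one.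

Compound 4 `CCCNC1=Nc2ccc(Cl)cc2C(C)(C)C1` differs from compound 3 by ethyl in place of hydrogen on a saturated chain carbon bound to an amine nitrogen, which read one bond further out is methyl to propyl, methylamino to propylamino. The step from compound 3 to compound 4 is expected to be small, a number 4.3 percentage points lower from compound 3 to compound 4 (within the scatter), most likely not beyond the scatter, with the direction uncertain. Compound 4 is therefore estimated to give about 88% in this assay, somewhere between 72% and 100%.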

Compound 4, a percentage reported as activity, at one concentration (the size of the read-out at that concentration, not a potency): 82.4%
Beside the measured number, compound 4's estimate is 5.6 percentage points above it, within the range that was stated.
By their numbers in this assay, from the lowest: compounds 1, 4, 3 and 2 (each within the scatter of the next, the first and the last beyond it).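

For the compounds shown here, the step on this position is the first that can be read on the shared core: in this assay, ethyl in place of hydrogen on a saturated chain carbon bound to an amine nitrogen, which extends methylamino to propylamino, gives a number 9.9 percentage points lower from compound 3 to compound 4 (within the scatter). This step stays within the scatter, so the methylamino and propylamino compounds cannot be put in order on this read-out, and this one change does not establish any effect of chain length. Nothing measured here offers an explanation for the size of this step.

On these data alone, it remains open whether a longer chain such as butyl, a benzyl group or a morpholine at this place would move the number beyond the scatter. With a single concentration behind each number, the potency of these compounds also remains open.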